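A few compounds are considered here, and "the series" means these few. Any claim that something is new, unique, unknown or untested is made for them only; others in the source may bear on it.

Of the compounds shown here, three have so far been measured in an assay on HEK293 cells for agonist activity at Toll-like receptor 8 (Homo sapiens), read by spectrophotometry; a higher number here means that more compound is needed for the effect, a lower number that less compound is needed. Compound 1 `CCCCNc1nc(N)nc(C)c1CCCCO` gives 1310 nM; compound 2 `CCCCNc1nc(N)nc(C)c1CCCN(C)C` gives 126 nM; compound 3 `CCCCNc1nc(N)nc(C)c1CCCN1CCCCCC1` gives 178 nM. Compound 2 has the lowest number of the three, though its gap to compound 3 lies within the scatter, so those two are not separated here. Compound 4 `C#Cc1c(C)nc(N)nc1NCCCC` differs from compound 2 by ethynyl in place of 3-(dimethylamino)propyl on an aromatic carbon, on an aromatic carbon of the shared core. Within the data shown here, the steps that bear on this are a 10-fold lower number from compound 1 to compound 2 (1.02 log units; beyond the scatter) and a 7.4-fold lower number from compound 1 to compound 3 (0.87 log units; beyond the scatter): either basic chain gave a clearly lower number than the hydroxymethyl chain, while a 1.4-fold higher number from compound 2 to compound 3 (0.15 log units; within the scatter) shows the size of that chain end barely registers. Compound 4 keeps neither the dimethylamino chain nor a hydroxymethyl chain, so the expected step is a 24-fold higher number from compound 2 to compound 4 (1.38 log units; beyond the scatter), toward a higher number. Compound 4 is estimated at 3000 nM, within 800 nM to 12000 nM.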

Compound 4, half-maximal effective concentration: 4900 nM
The estimate for compound 4 lay 1.6-fold (0.21 log units) below the measured number, within the range that was stated.
By their numbers in this assay, from the lowest: compounds 2 and 3 (each within the scatter of the next); then compound 1; then compound 4.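

Replacing 3-(dimethylamino)propyl with the shorter ethynyl, which has no nitrogen, costs a great deal at this aromatic carbon (a 39-fold higher number from compound 2 to compound 4 (1.59 log units; beyond the scatter)). Ethynyl also falls behind the 4-hydroxybutyl chain, which has no amine (a 3.7-fold higher number from compound 1 to compound 4 (0.57 log units; beyond the scatter)), so the amine end is not the only feature that separates these groups. No measured evidence accompanies these steps, and their cause stays unknown.

Going by these compounds, how much depends on chain length and how much on the group at its end remains open. A shorter 2-(dimethylamino)ethyl chain and a plain butyl chain would help to separate the two.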